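Indole dinitrile and sulfonyl nitrile series: growth inhibition notes

This account rests on a few compounds, and the source may have more. Where it says the series, first, only, none or still open, it means among the compounds named here.

Measured compounds:
compound 1 `COc1ccc2[nH]c(-c3ccccc3)c(C=C(C#N)C#N)c2c1` 3200 nM
compound 2 `COc1ccc(-c2[nH]c3ccc(OC)cc3c2C=C(C#N)C#N)cc1` 778 nM
compound 3 `COc1ccc2[nH]c(-c3ccccc3)c(/C=C(\C#N)S(=O)(=O)c3ccccc3)c2c1` 4000 nM

In a functional assay on HCT-15 cells (Homo sapiens) for inhibition, read by sulforhodamine B assay, with a stated time of 48 h (a higher number here means a weaker inhibitor of growth, a lower number a stronger inhibitor of growth), compound 3 gives 4000 nM, the highest of the three numbers, and compound 1 gives 3200 nM, within the scatter of it; compound 2 gives 778 nM. The difference between the core of compound 3 and that of compound 2 is not broken down here.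

One change recurs. From compound 2 to compound 1 the change hydrogen in place of methoxy on an aromatic carbon gave a 4.1-fold higher number from compound 2 to compound 1 (0.61 log units; beyond the scatter). Compound 4 `N#C/C(=C\c1c(-c2ccccc2)[nH]c2ccccc12)S(=O)(=O)c1ccccc1` carries the same kind of change from compound 3, (hydrogen in place of methoxy on an aromatic carbon), but the place differs: in compound 4 the group leaves a ring that is part of a fused or bridged system of two rings, whereas in compound 1 it leaves a carbon para to a large group. The step from compound 3 to compound 4 in this assay is expected to be a 2.0-fold higher number from compound 3 to compound 4 (0.30 log units; within the scatter), resting on the step from compound 2 to compound 1 and on compound 3 giving 4000 nM. Compound 4 is thus estimated at 8000 nM, between 3000 nM and 25000 nM.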

Compound 4, concentration for 50% growth inhibition: 1100 nM
The estimate for compound 4 lay 7.3-fold (0.86 log units) above the measured number, and the stated range ends above it.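

In this assay the change of methoxy to hydrogen gave a 3.6-fold lower number from compound 3 to compound 4 (0.56 log units; beyond the scatter), so the direction seen on the earlier core did not carry over: the same change on two cores in this assay, a 4.1-fold higher number (0.61 log units; beyond the scatter) from compound 2 to compound 1 and a 3.6-fold lower number (0.56 log units; beyond the scatter) from compound 3 to compound 4, 15-fold (1.17 log units) apart, beyond the scatter of two such steps Within these compounds, a step read on one core cannot be transferred to the other, in size or in direction. This does not show what sets the two steps apart, since the pairs differ both in the rest of the core and in the place the methoxy leaves.

Open, going by these compounds, is how each core answers when methoxy leaves the place it left on the other core. Also open, on these data alone, is how a hydroxyl, an amine or a longer ether chain would compare with methoxy on each core.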